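The source may hold more compounds than are shown below. What is called first, only, known or untested is meant among the compounds shown, and "the series" means these compounds.

Measured in a functional assay on HL-60 cells (Homo sapiens) for inhibition, read by MTT assay, with a stated time of 72 h; a lower number here means a stronger inhibitor, a higher number a weaker inhibitor:
- compound 1 `Cc1nc(-c2ccccc2)c(C(=O)N2CCN(c3cccc(Cl)c3)CC2)o1`: 39.2 nM
- compound 2 `Cc1nc(-c2ccccc2)c(C(=O)N2CCN(c3cccc(Cl)c3Cl)CC2)o1`: 133 nM

Of these two compounds, compound 1 holds the lower number, at 39.2 nM, and so stands as the stronger inhibitor in this assay. The next compound, compound 3 `Cc1nc(-c2ccccc2Cl)c(C(=O)N2CCN(c3cccc(Cl)c3)CC2)o1`, keeps the core of compound 1 and changes one place: chloro in place of hydrogen on an aromatic carbon. In words, a chloro takes the place of a hydrogen on an aromatic carbon, turning phenyl into 2-chlorophenyl, ortho to a large group.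

Going by the values given here, only one measured step bears on this change, and it is an indirect guide. It also adds a chloro in place of a hydrogen on an aromatic carbon, but at another place in the molecule: a 3.4-fold higher number from compound 1 to compound 2 (0.53 log units; beyond the scatter). Among the compounds with values here, that modest step is the only evidence for the direction, and no measured compound carries a chloro on the phenyl itself. A modest rise in the number is therefore expected, though with wide uncertainty, and no change beyond the scatter remains possible. The expected step is a 1.9-fold higher number from compound 1 to compound 3 (0.28 log units; within the scatter). For compound 3 the estimated value is 75 nM, with an expected range from 20 nM to 280 nM.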

Compound 3, half-maximal inhibitory concentration: 132 nM
Compound 3: middle estimate off by 1.8-fold (0.25 log units), on the low side; the range from low to high includes it.
By their numbers in this assay, from the lowest: compound 1; then compounds 3 and 2 (each within the scatter of the next).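

With compound 3, the phenyl itself now has a direct reading: in this assay, the change from phenyl to 2-chlorophenyl gives a 3.4-fold higher number from compound 1 to compound 3 (0.53 log units; beyond the scatter). The earlier compounds shown here showed a penalty for a chloro only at another place in the molecule, and this step shows that the phenyl, at this place ortho to a large group, does not tolerate the same swap of hydrogen for chloro without a loss; both single chloro additions to compound 1 move the number the same way, as the earlier 3.4-fold higher number from compound 1 to compound 2 (0.53 log units; beyond the scatter) shows. Nothing available explains why a chloro at this position raises the number.

The compounds shown leave open whether a smaller or different group in the same place, such as fluoro, methyl or methoxy, would also raise the number, and whether the rise belongs to chloro in particular or to any group there. They also leave open how a chloro elsewhere on the phenyl would read, and whether the two chloro changes would add up if carried together in one compound.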